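Open-chain oxime ether at the aryl substituent position

The source may report more compounds than this note shows. Statements on the series, on what has been measured and on what is new or still open speak of the compounds shown alone.

Within the data shown here, compound 2 `Cc1nc(-c2ccccc2NCC2=NCCN2)no1` gives the highest of the two numbers so far in a functional assay for activation of Alpha-1A adrenergic receptor (Homo sapiens), read by calcium flux (a higher number here means that more compound is needed for the effect, a lower number that less compound is needed), at 724 nM; its nearest neighbour is compound 1 `Cc1nc(-c2ccccc2NCC2=NCCN2)cs1`, which in this assay gives 4.47 nM, and the single measured step, a 160-fold higher number from compound 1 to compound 2 (2.21 log units; beyond the scatter), shows how strongly this position responds to a change of the attached group. Compound 3 `CC/C(=N/OC)c1ccccc1NCC1=NCCN1` takes the step further: a group of 6 heavy atoms (4 carbon, 1 nitrogen, 1 oxygen; no ring) in place of a group of 6 heavy atoms (3 carbon, 2 nitrogen, 1 oxygen; one five-membered aromatic ring with 3 hetero atoms), on an aromatic carbon. Among the measured compounds shown here, only the step from compound 1 to compound 2 bears on it, and it swapped one five-membered aromatic ring with hetero atoms for another; the group entering here has no ring at all, so that step does not fix the direction. The expected change, a 1.8-fold lower number from compound 2 to compound 3 (0.26 log units; within the scatter), is therefore set near no step beyond the scatter, with wide bounds. For compound 3 the estimate in this assay is 400 nM, expected between 40 nM and 4000 nM.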

Compound 3, half-maximal effective concentration: 87.1 nM
Compound 3: the middle estimate sits 4.6-fold (0.66 log units) above what was measured; measured number inside the range.
By their numbers in this assay, from the lowest: compound 1; then compound 3; then compound 2.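

In this assay, an 8.3-fold lower number from compound 2 to compound 3 (0.92 log units; beyond the scatter) and a 19-fold higher number from compound 1 to compound 3 (1.29 log units; beyond the scatter) place the group with no ring between the two groups bearing five-membered aromatic rings. An aromatic ring at this place on the aromatic carbon is therefore not needed for a number lower than that of compound 2, yet among the three groups shown the 2-methyl-1,3-thiazol-4-yl group of compound 1 still gives the lowest number. Nothing measured here explains this order.

From the compounds shown here alone, it remains open how much of the change from compound 2 belongs to the loss of the ring and how much to the oxime ether itself, as the two change together in this single step. Also open, going by these compounds, is whether a ketone, an amide or a longer chain on the oxime oxygen would bring the number closer to that of compound 1.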